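The source may report more compounds than this note shows. Statements on the series, on what has been measured and on what is new or still open speak of the compounds shown alone.

In an ADME assay on Vero cells (Chlorocebus sabaeus) for cytotoxicity, with a stated time of 7 days (a lower number here means that less compound is tolerated, a higher number that more compound is tolerated), three compounds have been measured:

Compound 1 `COc1cccc(CN2C(=O)CN(C(=O)c3cc4cc(OC)ccc4o3)C[C@@H]2CCc2ccccc2)c1` gives 4500 nM as a measured number.
Compound 2 `COc1cccc(CN2C(=O)CN(C(=O)c3cc4cc(OC)ccc4[nH]3)C[C@@H]2Cc2ccccn2)c1` gives > 10000 nM as a limit, not a number.
Compound 3 `COc1ccc2[nH]c(C(=O)N3CC(=O)N(Cc4ccccc4)[C@@H](Cc4ccccn4)C3)cc2c1` gives > 30000 nM as a limit, not a number.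

Compound 3 therefore has no exact place on this scale, and only its limit is known. Compound 4 `COc1ccc2[nH]c(C(=O)N3CC(=O)N(Cc4ccccc4)[C@@H](CN4CC5(CCC5)C4)C3)cc2c1` differs from it by one change: a group of 7 heavy atoms (6 carbon, 1 nitrogen; one four-membered non-aromatic ring of carbon only, one four-membered non-aromatic ring with 1 hetero atom) in place of a group of 6 heavy atoms (5 carbon, 1 nitrogen; one six-membered aromatic ring with 1 hetero atom), on a saturated chain carbon bound to a saturated ring carbon. Among the compounds with values here, the only measured step, a step that the two limits leave unreadable from compound 2 to compound 3, is a different structural change and cannot be read, so it offers no size to carry over. Within the data shown here, no measured step covers the change to compound 4. Compound 1 gives 4500 nM and so shows that a compound of this kind can yield a number in this assay. On that slim basis, a moderate move towards lower tolerance is expected, though the assay may again report only a limit. The estimated step is an at least 1.5-fold lower number from compound 3 to compound 4 (0.17 log units; that floor lies within the scatter) and remains loose. For compound 4 the estimate is 20000 nM, with an expected range from 7000 nM to 50000 nM.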

Compound 4, half-maximal cytotoxic concentration: 52700 nM
Beside the measured number, compound 4's estimate is 2.6-fold (0.42 log units) below it; measured number outside the range, above it.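

No step from compound 3 to compound 4 can be read, because compound 3 carries only a limit and not a number: the limit of > 30000 nM in this assay, at which 1 of the 4 values shown sits.

The compounds shown leave open whether, in this assay, compound 4 is tolerated at a higher or lower concentration than compound 3, and so how far the loss of pyridin-2-yl moves the read-out.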